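The source may report more compounds than this note shows. Statements on the series, on what has been measured and on what is new or still open speak of the compounds shown alone.

In a functional assay on HT-29 cells (Homo sapiens) for inhibition, read by CCK-8 assay, with a stated time of 24 h (on this read-out lower numbers stand for stronger inhibition and higher numbers for weaker inhibition), compound 1 `O=C1Nc2ccc(F)cc2/C1=C/c1ccc(-c2cn(-c3ccccc3F)nn2)cc1` gives 8980 nM. Compound 2 `O=C1Nc2ccc(F)cc2/C1=C/c1ccc(-c2cn(-c3cccc(F)c3)nn2)cc1` gives only a limit, > 12900 nM, and no number. Compound 3 `O=C1Nc2ccc(F)cc2/C1=C/c1ccc(-c2cn(-c3ccc(F)cc3)nn2)cc1` differs from compound 2 by 4-fluorophenyl in place of 3-fluorophenyl on an aromatic nitrogen. Going by the values given here, the one measured step that bears on this is the same kind of swap on that nitrogen, an at least 1.4-fold higher number from compound 1 to compound 2 (0.15 log units; that floor lies within the scatter). On that evidence, no step beyond the scatter is expected in this assay, in either direction. The expected change is an at least 1.0-fold lower number from compound 2 to compound 3 (0.03 log units; that floor lies within the scatter). Compound 3 is estimated at 12000 nM, with an expected range of 5000 nM to 30000 nM.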

Compound 3, half-maximal inhibitory concentration: 20000 nM
Estimate against measurement, compound 3: 1.7-fold (0.22 log units) below; low and high end bracket the measured number.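

In this assay, the swap on the aromatic nitrogen now gives a readable step beyond the scatter: 4-fluorophenyl in place of 2-fluorophenyl gives a 2.2-fold higher number from compound 1 to compound 3 (0.35 log units; beyond the scatter), a modest change between two groups with the same atom counts. The earlier pair gave only a floor within the scatter. The step from compound 2 to compound 3 cannot be read, because compound 2 carries only a limit: the limit of > 12900 nM in this assay, at which 1 of the 3 values shown sits.

Still open, going by these compounds, is how an unsubstituted phenyl compares with these fluorophenyl groups. Also open, on these data alone, is whether an amine or a carboxylic acid on that phenyl ring would shift the number.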